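A Fluorophenyl Replacement on the Shared Core

The source may report more compounds than this note shows. Statements on the series, on what has been measured and on what is new or still open speak of the compounds shown alone.

Of the compounds shown here, two have been tested in a functional assay on PC-3 cells (Homo sapiens) for cytotoxicity, read by MTT assay, with a stated time of 72 h; on this read-out higher numbers stand for weaker inhibition and lower numbers for stronger inhibition. Compound 1 `COc1ccc(Nc2nc3ccccc3nc2S(=O)(=O)c2ccc(Br)cc2)cc1` gives 1110 nM, and compound 2 `Nc1cccc(Nc2nc3ccccc3nc2S(=O)(=O)c2ccc(Br)cc2)c1` gives 9010 nM. For the measured compounds named here, compound 2 therefore carries the highest, that is the weakest, number of the two, and the only measured step, an 8.1-fold higher number from compound 1 to compound 2 (0.91 log units; beyond the scatter), shows that the group attached to that nitrogen shifts the read-out well beyond the scatter.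

Compound 3 `O=S(=O)(c1ccc(Br)cc1)c1nc2ccccc2nc1Nc1ccc(F)cc1` has not yet been measured. It differs from compound 2 in one place: 4-fluorophenyl in place of 3-aminophenyl on a nitrogen on an aromatic ring. The incoming 4-fluorophenyl, like the 4-methoxyphenyl of compound 1, brings no hydrogen-bond donor or acceptor, whereas the leaving 3-aminophenyl did.

Going by the values given here, only the step from compound 1 to compound 2 bears on this change, and it was modest. Compound 1, with its 4-methoxyphenyl, gives 1110 nM. On that basis the expected step is a 4.1-fold lower number from compound 2 to compound 3 (0.61 log units; beyond the scatter), a move toward a lower, stronger number rather than none at all. Compound 3 is thus estimated at 2200 nM, with a range from 700 nM to 7000 nM.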

Compound 3, half-maximal inhibitory concentration: 9160 nM
Compound 3: the middle estimate sits 4.2-fold (0.62 log units) below what was measured; the whole stated range lies below it.
By their numbers in this assay, from the lowest: compound 1; then compounds 2 and 3 (each within the scatter of the next).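

In this assay, putting 4-fluorophenyl in place of 3-aminophenyl on the nitrogen gives a 1.0-fold higher number from compound 2 to compound 3 (0.01 log units; within the scatter). These two groups therefore cannot be told apart on this read-out, even though the 3-aminophenyl counts 1 hydrogen-bond donor and the 4-fluorophenyl counts 0 hydrogen-bond donors. The clear difference at this position lies elsewhere: fluoro in place of methoxy on an aromatic carbon gives an 8.3-fold higher number from compound 1 to compound 3 (0.92 log units; beyond the scatter), which leaves compound 1, with its 4-methoxyphenyl, as the strongest of the three and shows that removing the amino group is not enough to reach its number. No measurement is available to explain this difference.

On these data alone, it remains open whether the stronger number of compound 1 belongs to the methoxy group itself, which a plain phenyl, a 4-hydroxyphenyl or a 4-ethoxyphenyl on the same nitrogen could help to settle. As far as these compounds go, it is also open whether the same pattern would hold if the bromo group on the other aromatic ring were exchanged for a chloro group or a methyl group.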